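This account rests on a few compounds, and the source may have more. Where it says the series, first, only, none or still open, it means among the compounds named here.

Working notes on the series in an assay on HeLa cells for inhibition of sphingosine-1-phosphate transporter SPNS2 (Mus musculus), read by LC-MS, tested at 2 uM; a higher number here means more inhibition at the concentration tested (going by the name of the read-out), a lower number less inhibition.

For the measured compounds named here, compound 1 `CCCCCCCCCCc1ccc(-c2noc(CCCN(C)C)n2)cc1` gives 8% in this assay, the lowest of the three numbers measured so far. Compound 3 `CCCCCCCCCCc1ccc(-c2noc([C@H]3CCCN3)n2)cc1` gives 12%, which lies a number 4 percentage points higher from compound 1 to compound 3 (within the scatter), within the scatter. Compound 2 `CCCCCCCCCCc1ccc(-c2noc(CC3CCNC3)n2)cc1` gives 44%, and the step there runs a number 36 percentage points higher from compound 1 to compound 2 (beyond the scatter), well beyond the scatter; set against compound 2, compound 3 runs a number 32 percentage points lower from compound 2 to compound 3 (beyond the scatter).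

Compound 4 `CCCCCCCCCCc1ccc(-c2noc(-c3cccc(CN)c3)n2)cc1` is not yet measured. Its difference from compound 1 is 3-(aminomethyl)phenyl in place of 3-(dimethylamino)propyl on an aromatic carbon. Both measured steps from compound 1 also exchange the 3-(dimethylamino)propyl chain for a nitrogen-bearing group, so they bear on this step, but neither introduces an aromatic ring or an aminomethyl group. One of them, a number 36 percentage points higher from compound 1 to compound 2 (beyond the scatter), was large; the other, a number 4 percentage points higher from compound 1 to compound 3 (within the scatter), was within the scatter. The direction of the two replacements therefore points upward, but the size is unsettled.

Compound 4 is expected to sit somewhat above compound 1, estimated at 25%, with a range from 5% to 55%, meaning an expected step of a number 17 percentage points higher from compound 1 to compound 4 (beyond the scatter).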

Compound 4, a percentage reported as inhibition, at one concentration (the size of the read-out at that concentration, not a potency): 2%
Compound 4: the middle estimate sits 23 percentage points above what was measured; the whole stated range lies above it.
By their numbers in this assay, from the lowest: compounds 4, 1 and 3 (each within the scatter of the next); then compound 2.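

In this assay, 3-(aminomethyl)phenyl on the aromatic carbon of the five-membered ring gives a number 6 percentage points lower from compound 1 to compound 4 (within the scatter) and a number 10 percentage points lower from compound 3 to compound 4 (within the scatter), so the scatter does not separate this group from 3-(dimethylamino)propyl or pyrrolidin-2-yl. The same replacement gives a number 42 percentage points lower from compound 2 to compound 4 (beyond the scatter), which shows that a nitrogen-bearing group at this position does not by itself carry the reading of compound 2, and that a six-membered aromatic ring of carbon only bearing aminomethyl does not reproduce it; among the four groups seen here, (pyrrolidin-3-yl)methyl alone stands apart. No supporting data account for the gap between this group and the other three.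

The compounds shown leave open whether the reading of compound 2 holds with a piperidine in place of its pyrrolidine ring, or with a methyl group on the ring nitrogen. They also leave open how a carboxylic acid would read at this position, which would show whether an amine is needed there at all.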